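A few compounds are considered here, and "the series" means these few. Any claim that something is new, unique, unknown or untested is made for them only; others in the source may bear on it.

Compound 1 `Cc1cccc(N2C(=O)CSC2c2cccc(C(=O)NCCCCc3ccccc3)c2)c1` gives 749 mL.min-1.g-1 in an ADME assay on microsomes from liver (Canis lupus familiaris) for metabolic stability, read by LC-MS, using NADPH, with a stated time of 10 min, tested at 0.1 uM; a higher number here means faster removal of the compound, a lower number slower removal. Compound 3 `O=C(NCCCCc1ccccc1)c1cccc(C2SCC(=O)N2c2cccc(F)c2)c1` gives 837 mL.min-1.g-1 in this assay; the change from compound 1 is fluoro in place of methyl on an aromatic carbon, and the step is a 1.1-fold higher number from compound 1 to compound 3 (0.05 log units; within the scatter). Compound 2 `Cc1ccnc(N2C(=O)CSC2c2cccc(C(=O)NCCCCn3cccn3)c2)c1` gives 41.8 mL.min-1.g-1 in this assay, the lowest of the three numbers; how its core differs from that of compound 1 is not broken down here. Compound 4 `O=C(NCCCCn1cccn1)c1cccc(C2SCC(=O)N2c2cc(F)ccn2)c1` is not yet measured; from compound 2 the change is fluoro in place of methyl on an aromatic carbon. This is the same kind of change as from compound 1 to compound 3, though here the ring holds one nitrogen and the place is opposite the ring nitrogen. Resting on the step of a 1.1-fold higher number from compound 1 to compound 3 (0.05 log units; within the scatter), the step from compound 2 to compound 4 is expected to be small, about a 1.1-fold higher number from compound 2 to compound 4 (0.06 log units; within the scatter). Compound 4 is therefore estimated at 48 mL.min-1.g-1 in this assay, between 22 mL.min-1.g-1 and 105 mL.min-1.g-1.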

Compound 4, intrinsic clearance in microsomes: 68.2 mL.min-1.g-1
For compound 4 the middle estimate is 1.4-fold (0.15 log units) below the measured one; the range from low to high includes it.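

In this assay, fluoro in place of methyl on an aromatic carbon gives a 1.6-fold higher number from compound 2 to compound 4 (0.21 log units; within the scatter). Set beside the earlier case, the change carries from one core to the other with no difference that can be told from the scatter: the same change on two cores in this assay, a 1.1-fold higher number (0.05 log units; within the scatter) from compound 1 to compound 3 and a 1.6-fold higher number (0.21 log units; within the scatter) from compound 2 to compound 4, 1.5-fold (0.16 log units) apart, within the scatter of two such steps. This rests on two pairs only and does not show that the step stays small on other cores or at other places on the ring, nor does it give any reason for the result.

Open, on these data alone, is how other groups behave at the place opposite the ring nitrogen, such as chloro, methoxy or an amine. As far as these compounds go, the parts in which compound 1 and compound 2 differ, taken one at a time, also remain open.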